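Does a longer amide chain change compound 2?

A few compounds are considered here, and "the series" means these few. Any claim that something is new, unique, unknown or untested is made for them only; others in the source may bear on it.

In a functional assay (trachea) with Cavia porcellus as the target (a lower number here means a stronger inhibitor, a higher number a weaker inhibitor), compound 1 (`O=c1c2ccccc2c(-c2cccnc2)nn1Cc1cccc(Cl)c1`) gives 4170 nM and compound 2 (`O=c1c2ccccc2c(-c2cccnc2)nn1CCO`) gives 4570 nM. These two numbers are the only ones available, and they cannot be told apart within the scatter of the measurement.

Compound 3 (`CC(C)NC(=O)CCCn1nc(-c2cccnc2)c2ccccc2c1=O`) has not been measured yet. It carries (isopropylcarbamoyl)methyl in place of the hydroxy of compound 2, on a saturated chain carbon, two bonds along the chain from an aromatic nitrogen: (isopropylcarbamoyl)methyl in place of hydroxy on a saturated chain carbon, two bonds along the chain from an aromatic nitrogen.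

Among the compounds with values here, one measured step bears on this change. It is a 1.1-fold higher number from compound 1 to compound 2 (0.04 log units; within the scatter), where hydroxymethyl takes the place of 3-chlorophenyl on the chain bound to the same aromatic nitrogen. Two quite different groups at this chain thus left the number in place, which gives no reason to expect a real shift in either direction.

No step beyond the scatter is expected in this assay, and the estimated step is a 1.1-fold lower number from compound 2 to compound 3 (0.06 log units; within the scatter). A single step is thin evidence, and the entering group resembles neither earlier one, so the range is kept wide. Compound 3 is expected at about 4000 nM, with an estimated range of 1000 nM to 12000 nM.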

Compound 3, half-maximal inhibitory concentration: 64600 nM
Estimate against measurement, compound 3: 16-fold (1.21 log units) below; the whole stated range lies below it.
By their numbers in this assay, from the lowest: compounds 1 and 2 (each within the scatter of the next); then compound 3.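

In this assay, the chain on the aromatic nitrogen proves not to be indifferent to what it carries: putting (isopropylcarbamoyl)methyl in place of hydroxy gives a 14-fold higher number from compound 2 to compound 3 (1.15 log units; beyond the scatter) and so a clearly weaker inhibitor. Measured against the other earlier compound, 2-(isopropylcarbamoyl)ethyl in place of 3-chlorophenyl gives a 15-fold higher number from compound 1 to compound 3 (1.19 log units; beyond the scatter) and points the same way, so the agreement between 3-chlorophenyl and hydroxymethyl did not mean that any group is accepted at this place. Nothing shown here gives a measured reason for this loss of activity.

The compounds shown leave open which part of the entering group matters, since the longer chain, the amide and the isopropyl group all arrive together in a single change. A plain butyl chain on the aromatic nitrogen, a carboxylic acid at the end of the same chain, or a primary amide in place of the isopropyl amide would begin to separate these parts.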